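Triazole sulfur substitution in a hepatoma antiproliferative series

This account rests on a few compounds, and the source may have more. Where it says the series, first, only, none or still open, it means among the compounds named here.

Compound 1 `Sc1nnc(-c2ccc3c(c2)OCCO3)n1-c1ccccc1` is the unsubstituted sulfur member of the series. Among the compounds with values here, in a functional assay on HepG2 cells (Homo sapiens) for antiproliferative activity, read by MTT assay, with a stated time of 24 h (a higher number here means a weaker inhibitor, a lower number a stronger inhibitor), compound 1 gives 60000 nM, the highest of the three numbers so far. Compound 2 `c1ccc(CSc2nnc(-c3ccc4c(c3)OCCO4)n2-c2ccccc2)cc1` gives 5960 nM, and compound 3 `COc1cccc(CSc2nnc(-c3ccc4c(c3)OCCO4)n2-c2ccccc2)c1` gives 35100 nM. The step of a 10-fold lower number from compound 1 to compound 2 (1.00 log units; beyond the scatter) is the clearest effect seen, whereas a 1.7-fold lower number from compound 1 to compound 3 (0.23 log units; within the scatter) stays within the scatter; between the two substituted members, a 5.9-fold higher number from compound 2 to compound 3 (0.77 log units; beyond the scatter).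

Compound 4 `Cc1ccc(CSc2nnc(-c3ccc4c(c3)OCCO4)n2-c2ccccc2)cc1` is not yet measured. Relative to compound 1 the change is 4-methylbenzyl in place of hydrogen on a sulfur. The two steps from compound 1 that bear on this, to compound 2 and to compound 3, both lower the number, one beyond the scatter and one within it, so a decrease is expected, most likely closer to the benzyl case than to the 3-methoxybenzyl case. The estimated step is a 6.7-fold lower number from compound 1 to compound 4 (0.82 log units; beyond the scatter). Compound 4 is therefore expected to give about 9000 nM in this assay, within a range of 3000 nM to 30000 nM.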

Compound 4, half-maximal inhibitory concentration: 56800 nM
Compound 4: the middle estimate sits 6.3-fold (0.80 log units) below what was measured; the measured number lies above the stated range.
By their numbers in this assay, from the lowest: compound 2; then compounds 3, 4 and 1 (each within the scatter of the next).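

Notes on the sulfur substituent: in this assay, the gain seen with benzyl does not carry over to 4-methylbenzyl, which leaves a 1.1-fold lower number from compound 1 to compound 4 (0.02 log units; within the scatter), and adding the methyl to the plain benzyl gives a 9.5-fold higher number from compound 2 to compound 4 (0.98 log units; beyond the scatter). The 4-methylbenzyl and 3-methoxybenzyl members cannot be told apart, with a 1.6-fold higher number from compound 3 to compound 4 (0.21 log units; within the scatter), so among the three substituted sulfur groups only the plain benzyl of compound 2 stands clear of compound 1. No measured data bear on the cause of this sensitivity to a single added group.

Open, from the compounds shown here alone, is whether the loss follows the identity of the added group or its place on the benzyl ring. 3-Methylbenzyl and 4-methoxybenzyl on the sulfur would separate these two readings, and phenethyl would test a longer chain.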